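Adding a tert-butyl group to a cytotoxic thiosemicarbazone

The compounds below may be only part of what the source reports. "The series", "measured", "known", "first", "only" and "open" are said of these compounds alone.

The starting point is compound 1 `O=C1Nc2ccccc2/C1=N/NC(=S)Nc1ccccc1`, which in a functional assay on KB 3-1 cells (Homo sapiens) for cytotoxicity, read by MTT assay, with a stated time of 72 h (on this read-out higher numbers stand for weaker inhibition and lower numbers for stronger inhibition), gives 3530 nM. Among the three numbers in hand this is the second highest: compound 2 `COc1ccccc1NC(=S)N/N=C1\C(=O)Nc2ccccc21` gives 4960 nM, and compound 3 `O=C1Nc2ccccc2/C1=N/NC(=S)Nc1cccc(Cl)c1` gives 1870 nM. Both of these differ from compound 1 by a single substituent on the outer aromatic ring, and both steps are small: a 1.4-fold higher number from compound 1 to compound 2 (0.15 log units; within the scatter), and a 1.9-fold lower number from compound 1 to compound 3 (0.28 log units; within the scatter), so neither change moved the cytotoxicity beyond the scatter of the measurement.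

Compound 4 `CC(C)(C)c1ccc(NC(=S)N/N=C2\C(=O)Nc3ccccc32)cc1` changes the same ring in one place: tert-butyl in place of hydrogen on an aromatic carbon. The two measured steps are the only ones that bear on this change, and each stayed within the scatter, so a large shift in the half-maximal inhibitory concentration is not expected here either. The estimate for compound 4 is therefore 3000 nM, with a range from 1200 nM to 8000 nM, which amounts to an expected step of a 1.2-fold lower number from compound 1 to compound 4 (0.07 log units; within the scatter).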

Compound 4, half-maximal inhibitory concentration: 8130 nM
Beside the measured number, compound 4's estimate is 2.7-fold (0.43 log units) below it; the measured number lies above the stated range.
By their numbers in this assay, from the lowest: compounds 3, 1, 2 and 4 (each within the scatter of the next, the first and the last beyond it).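

In this assay, for the compounds shown here, tert-butyl on an aromatic carbon para to a large group gives the first step in this set that lies beyond the usual scatter (a 2.3-fold higher number from compound 1 to compound 4 (0.36 log units; beyond the scatter)), although that step is modest. This shows that a single added group on this ring can measurably weaken inhibition, something the methoxy and chloro steps, both within the scatter, could not show. Nothing in the data at hand accounts for this shift.

From the compounds shown here alone, it remains open whether methyl, an amine or a carboxylic acid at this same place would also raise the number, or whether the step is particular to tert-butyl. Methoxy and chloro sit at other places on the ring, so it is also unclear how tert-butyl would behave at those places, or how either of those groups would behave at this one.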